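From 3-chloro-2-fluorophenyl to 3-chloro-4-fluorophenyl at the assay limit

This account rests on a few compounds, and the source may have more. Where it says the series, first, only, none or still open, it means among the compounds named here.

Compound 2 (`C=CC(=O)Nc1cc2c(Nc3cccc(Cl)c3F)ncnc2cc1OCc1cn(CCCCC(=O)NO)nn1`) gives > 50000 nM in a functional assay on A549 cells (Homo sapiens) for antiproliferative activity, read by MTT assay, with a stated time of 72 h (on this read-out lower numbers stand for stronger inhibition and higher numbers for weaker inhibition), and this value is a limit of the assay, not a number. Compound 1 (`C=CC(=O)Nc1cc2c(Nc3ccc(OCc4cccc(F)c4)c(Cl)c3)ncnc2cc1OCc1cn(CCCCC(=O)NO)nn1`) gives > 50000 nM in this assay and this too is a limit. Compound 3 (`C=CC(=O)Nc1cc2c(Nc3ccc(OCc4cccc(F)c4)c(Cl)c3)ncnc2cc1OCc1cn(CCC(=O)NO)nn1`) gives > 50000 nM in this assay and this is again a limit. Compound 2 therefore has no numerical position of its own, and the whole set is summed up as the limit of > 50000 nM in this assay, at which 3 of the 3 values shown sit, without any exception.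

Compound 4 (`C=CC(=O)Nc1cc2c(Nc3ccc(F)c(Cl)c3)ncnc2cc1OCc1cn(CCCCC(=O)NO)nn1`) has not yet been measured. Its difference from compound 2 lies in one place: 3-chloro-4-fluorophenyl in place of 3-chloro-2-fluorophenyl on a nitrogen on an aromatic ring with 3-chloro-4-fluorophenyl in place of 3-chloro-2-fluorophenyl on a nitrogen on an aromatic ring.

Going by the values given here, only one measured step exists, namely a step that the two limits leave unreadable from compound 1 to compound 3 in the chain ending in hydroxycarbamoyl and not in this aryl group. It offers no size to carry over to the new change. The expectation rests instead on compound 2 with its limit of > 50000 nM as the starting point. The expected step is an at least 1.1-fold lower number from compound 2 to compound 4 (0.04 log units; that floor lies within the scatter) and the data support no firm direction for it. Compound 4 is estimated at 45000 nM with an expected range from 15000 nM to 100000 nM in this assay.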

Compound 4, half-maximal inhibitory concentration: > 50000 nM
Compound 4 ended at the assay's limit; the forecaster's own chance of this, stated with the estimate: 65%; middle value at least 1.1-fold (0.04 log units) away from the limit.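

Compound 4 gives > 50000 nM in this assay, and this is a limit of the assay, not a number. No step from compound 2 or compound 1 to compound 4 can be read, and the set stands at one value: the limit of > 50000 nM in this assay, at which 4 of the 4 values shown sit.

The compounds shown leave open how 3-chloro-4-fluorophenyl and 3-chloro-2-fluorophenyl compare in this assay.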